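Aryl swap on the piperazine nitrogen of a diaminoquinazoline series

The source may hold more compounds than are shown below. What is called first, only, known or untested is meant among the compounds shown, and "the series" means these compounds.

Measured compounds:
compound 1, `Nc1nc(N)c2cc(CSC(=S)N3CCN(c4ccc(O)cc4)CC3)ccc2n1`, 5090 nM
compound 2, `Nc1nc(N)c2cc(CSC(=S)N3CCN(c4ccccc4F)CC3)ccc2n1`, 4840 nM

The two compounds measured in a functional assay on MCF7 cells (Homo sapiens) for antiproliferative activity, read by MTT assay, with a stated time of 72 h (on this read-out lower numbers stand for stronger inhibition and higher numbers for weaker inhibition), share one core and differ only in the aryl group on an amine nitrogen in a ring. Compound 1 gives 5090 nM in this assay, and compound 2 gives 4840 nM. The step of a 1.1-fold lower number from compound 1 to compound 2 (0.02 log units; within the scatter) is within the scatter, so the two values cannot be ordered; compound 2 merely has the lowest of the two numbers, with compound 1 its nearest neighbour.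

Compound 3, `Nc1nc(N)c2cc(CSC(=S)N3CCN(c4ncccn4)CC3)ccc2n1`, is not yet measured. Its change from compound 2 is pyrimidin-2-yl in place of 2-fluorophenyl on an amine nitrogen in a ring. For the measured compounds named here, the only step that bears on it is the aryl exchange from compound 1 to compound 2, which left this assay unchanged within the scatter. On that single precedent, the expected step of a 1.1-fold higher number from compound 2 to compound 3 (0.06 log units; within the scatter) is none beyond the scatter, in either direction. Compound 3 is therefore estimated at 5500 nM in this assay, with a range from 2500 nM to 12000 nM.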

Compound 3, half-maximal inhibitory concentration: 4190 nM
Beside the measured number, compound 3's estimate is 1.3-fold (0.12 log units) above it; the measured number falls inside the stated range.
By their numbers in this assay, from the lowest: compounds 3, 2 and 1 (each within the scatter of the next).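

Pyrimidin-2-yl in place of 2-fluorophenyl gives a 1.2-fold lower number from compound 2 to compound 3 (0.06 log units; within the scatter) in this assay, and the same group in place of 4-hydroxyphenyl gives a 1.2-fold lower number from compound 1 to compound 3 (0.08 log units; within the scatter) in that read-out. Up to now, the aryl groups on this amine nitrogen in a ring had all been six-membered aromatic rings of carbon only; compound 3 extends the set to a six-membered aromatic ring with 2 hetero atoms and 2 hydrogen-bond acceptors, and its value still lies within the scatter of both others, so the three compounds cannot be ordered and no group at this position stands apart. Nothing available here accounts for how closely these values lie together.

As far as these compounds go, all three groups at this position are six-membered aromatic rings, and it remains open whether a group of another kind there, such as a carboxylic acid, a primary amine or a longer alkyl chain, would give a value beyond the scatter of these three. The shared core is the same in every compound shown, and what a change elsewhere in it would do to the value in this assay also remains open.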